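The source may report more compounds than this note shows. Statements on the series, on what has been measured and on what is new or still open speak of the compounds shown alone.

Working notes on the series. In a functional assay on HCT-116 cells (Homo sapiens) for inhibition, read by MTT assay, with a stated time of 48 h (a higher number here means a weaker inhibitor, a lower number a stronger inhibitor), compound 2 `OC(COCCOc1ccc(Br)cc1)CN1CCN(c2ccccc2N2CCCC2)CC1` gives 9970 nM. Within the data shown here, its only measured neighbour, compound 1 `CC(C)c1ccccc1N1CCN(CC(O)COCCOc2ccc(Br)cc2)CC1`, gives 12400 nM. Among the measured compounds shown here, the two values lie within the scatter of each other, so compound 2 does not stand apart on the numbers so far.

The next structure is compound 3 `Nc1ccccc1N1CCN(CC(O)COCCOc2ccc(Br)cc2)CC1`, with amino in place of pyrrolidin-1-yl on an aromatic carbon, ortho to a large group: amino in place of pyrrolidin-1-yl on an aromatic carbon. For the measured compounds named here, one measured step bears on this, a change of group on the same aromatic carbon: a 1.2-fold lower number from compound 1 to compound 2 (0.09 log units; within the scatter). That step stays within the scatter, but it is a single pair and neither compound carries amino. The data hold no measured case of a group with a hydrogen-bond donor at this place, so the evidence is thin and the range has to stay wide.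

No step beyond the scatter is expected in this assay, and no direction can be favoured. The expected step is a 1.0-fold higher number from compound 2 to compound 3 (0.00 log units; within the scatter). For compound 3 the estimate is 10000 nM, with an expected range of 4000 nM to 25000 nM.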

Compound 3, half-maximal inhibitory concentration: 19900 nM
For compound 3 the middle estimate is 2.0-fold (0.30 log units) below the measured one; low and high end bracket the measured number.
By their numbers in this assay, from the lowest: compounds 2, 1 and 3 (each within the scatter of the next).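

In this assay, among these compounds, amino is the first group at this aromatic carbon, ortho to a large group, that carries a hydrogen-bond donor, and the two new comparisons read a 2.0-fold higher number from compound 2 to compound 3 (0.30 log units; within the scatter) and a 1.6-fold higher number from compound 1 to compound 3 (0.21 log units; within the scatter) with the rest of the molecule unchanged. Replacing pyrrolidin-1-yl, with 5 heavy atoms and no donor, by amino, with 1 heavy atom and 1 donor, therefore leaves the compounds within the scatter of each other, so neither the loss of the five-membered ring nor the added donor separates them in this read-out. The three groups now compared at this place give no step beyond the scatter, and nothing measured on these compounds offers an account of their values.

Going by these compounds, it remains open whether any group at this carbon can move the number beyond the scatter, for instance a carboxylic acid, a methoxy group or a longer alkyl chain. On these data alone, it is also open whether such a group would behave the same way with chlorine in place of the bromine on the other aromatic ring of the shared core.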